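The compounds below may be only part of what the source reports. "The series", "measured", "known", "first", "only" and "open" are said of these compounds alone.

Compound 1 (`C[C@@H]1CN(c2cccc3ccccc23)CCN1CN1CC(=O)N2CCC[C@@H]2C1=O`) carries a methyl on the piperazine and joins the naphthylpiperazine to the bicyclic dione through a single methylene. In an assay on membranes from Cerebral cortex for binding affinity to Adrenergic receptor alpha-1 (Rattus norvegicus) (on this read-out higher numbers stand for weaker inhibition and lower numbers for stronger inhibition), compound 1 gives > 1000 nM, which is a limit of the assay rather than a number. The same limit is reached by compound 3 (`O=C1C2CCCN2C(=O)N1CN1CCN(c2cccc3[nH]cnc23)CC1`), which in this assay gives > 1000 nM; that, too, is a limit. Compound 2 (`O=C1C2CCCN2C(=O)CN1CCCCN1CCN(c2cccc3ccccc23)CC1`), which links the two halves through a four-carbon chain, gives 8 nM in this assay. Among the values shown, compound 1 therefore sits at the weak end, at the limit, with compound 3 beside it; only compound 2 gives a measurable number, and the limit of > 1000 nM in this assay, at which 2 of the 3 values shown sit, summarises how the data are distributed.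

Compound 4 (`C[C@H]1CN(c2cccc3ccccc23)CCN1CN1CC(=O)N2CCC[C@H]2C1=O`) is the mirror image of compound 1: the two compounds have the same atoms and bonds and differ only in configuration as drawn: 2 of 2 stereo elements differ (all stereocentres are inverted: mirror images); a stereocentre at a saturated ring carbon is drawn R in compound 1 and S in compound 4; a stereocentre at a saturated ring carbon is drawn R in compound 1 and S in compound 4. Within the data shown here, no step between measured compounds is available, so the expected size of the step from compound 1 to compound 4 rests on the two limits only: both methylene-linked compounds sit at the limit, so no change beyond the scatter is expected, and compound 4 is estimated at 2000 nM (range 500 nM to 10000 nM), a step that the limit leaves unreadable from compound 1 to compound 4.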

Compound 4, inhibition constant: > 1000 nM
Compound 4 ended at the assay's limit (the forecaster's own chance of this, stated with the estimate: 70%); the middle value is on the limit's open side.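

In this assay compound 4 gives > 1000 nM, a limit of the assay and not a number. Compound 1 also sits at a limit, so no step can be read between compound 1 and compound 4. The compounds shown leave open whether these two mirror images differ in affinity at all.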